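The compounds below may be only part of what the source reports. "The series", "measured", "known", "first", "only" and "open" are said of these compounds alone.

Compound 1 `C/C(=C\CC/C(C)=C/CC[C@@H]1[C@@]2(C)CCC(=O)C(C)(C)[C@H]2CC[C@@]1(C)O)CC/C=C(\C)C(=O)OCc1cn(C[C@@H]2O[C@H](n3ccc(=O)[nH]c3=O)C[C@H]2O)nn1` gives 33100 nM in a functional assay on DU-145 cells (Homo sapiens) for antiproliferative activity, read by MTT assay, with a stated time of 48 h; a lower number here means a stronger inhibitor, a higher number a weaker inhibitor.
Compound 2 `C/C(=C\CC/C(C)=C/CC[C@@H]1[C@@]2(C)CCC(=O)C(C)(C)[C@H]2CC[C@@]1(C)O)CC/C=C(\C)C(=O)OCc1cn(-c2cccc(Br)c2)nn1` gives only a limit of the assay, > 150000 nM.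
Compound 3 `C/C(=C\CC/C(C)=C/CC[C@@H]1[C@@]2(C)CCC(=O)C(C)(C)[C@H]2CC[C@@]1(C)O)CC/C=C(\C)C(=O)O` also gives only a limit of the assay, > 150000 nM.

Three compounds share the same large core, and they differ in what hangs from its acid end. Compound 1 is the only one of the three that returns a number. Among the measured compounds shown here, compound 2 stands at the limit of the assay, and so it cannot be ranked against compound 3, which returns the same limit; the two values show only that neither compound is an inhibitor within the reach of the assay, as summed up by the limit of > 150000 nM in this assay, at which 2 of the 3 values shown sit.

Compound 4 `C/C(=C\CC/C(C)=C/CC[C@@H]1[C@@]2(C)CCC(=O)C(C)(C)[C@H]2CC[C@@]1(C)O)CC/C=C(\C)C(=O)OCc1cn(-c2cccc(C(F)(F)F)c2)nn1` has not yet been measured. It differs from compound 2 in one place: trifluoromethyl in place of bromo on an aromatic carbon. For the measured compounds named here, no pair of measured compounds differs in a single place, so there is no measured step to lean on. Given that compound 2 sits at the limit, the change from compound 2 to compound 4 is expected to produce no step beyond the usual scatter, and compound 4 is expected to return a limit as well.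

Compound 4 is therefore estimated at 200000 nM, with a range from 60000 nM to 700000 nM. The expected step that the limit leaves unreadable from compound 2 to compound 4 is none beyond the scatter.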

Compound 4, half-maximal inhibitory concentration: > 150000 nM
Compound 4 was reported as a limit (the forecaster's own chance of this, stated with the estimate: 80%); the middle value lies beyond the limit too.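

Among the compounds shown here, compound 4, like compound 2, returns only a limit of the assay, so no step from one to the other can be read: the limit of > 150000 nM in this assay, at which 3 of the 4 values shown sit.

The compounds shown leave open whether 3-bromophenyl and 3-(trifluoromethyl)phenyl differ at all in this assay, and which part of compound 1 lets it return a number.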